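Cyclopropyl for isobutyl on the ring amide nitrogen

A few compounds are considered here, and "the series" means these few. Any claim that something is new, unique, unknown or untested is made for them only; others in the source may bear on it.

Among the compounds with values here, compound 2 `CC(C)CN1Cc2cc(OCc3cccc(-c4ccc(Cl)c(C(=O)O)c4)c3)ccc2C1=O` gives 100 nM in an assay on HEK293 cells for positive allosteric modulation of metabotropic glutamate receptor 2 (Rattus norvegicus), read by thallium flux (a lower number here means that less compound is needed, a higher number that more compound is needed for the effect), one of two numbers so far; compound 1 `O=C(O)c1cc(-c2cccc(COc3ccc4c(c3)CN(C3CCC3)C4=O)c2)ccc1Cl`, at 90 nM, sits within the scatter of it. Within the data shown here, the single comparable step, a 1.1-fold higher number from compound 1 to compound 2 (0.05 log units; within the scatter), exchanged cyclobutyl for isobutyl on the same nitrogen. Compound 3 `O=C(O)c1cc(-c2cccc(COc3ccc4c(c3)CN(C3CC3)C4=O)c2)ccc1Cl` carries cyclopropyl in place of isobutyl on an amide-type nitrogen in a ring. Because a 1.1-fold higher number from compound 1 to compound 2 (0.05 log units; within the scatter) stayed within the scatter, no step beyond the scatter is expected in this assay for compound 3. Compound 3 is therefore estimated at 95 nM, range 45 nM to 200 nM. The expected step is a 1.1-fold lower number from compound 2 to compound 3 (0.02 log units; within the scatter).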

Compound 3, half-maximal effective concentration: 220 nM
Compound 3: middle estimate off by 2.3-fold (0.36 log units), on the low side, outside the stated range (above it).
By their numbers in this assay, from the lowest: compounds 1 and 2 (each within the scatter of the next); then compound 3.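

On the amide-type nitrogen in a ring, the choice of group does register in this assay: cyclopropyl gives a 2.2-fold higher number from compound 2 to compound 3 (0.34 log units; beyond the scatter) and a 2.4-fold higher number from compound 1 to compound 3 (0.39 log units; beyond the scatter), whereas isobutyl and cyclobutyl remained within the scatter of each other. Both steps are modest and point the same way, so this position tolerates some exchanges but not all of them. No available data account for the difference.

Still open, from the compounds shown here alone, is whether a longer chain or a benzyl group on this nitrogen would stay level with compound 1 or move further from it.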